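Bromine Position on a Benzyl Group and Cell Tolerance

The source may report more compounds than this note shows. Statements on the series, on what has been measured and on what is new or still open speak of the compounds shown alone.

Compound 1 `Cc1c(Cc2ccccc2Br)nc(SCc2ccc([N+](=O)[O-])cc2)[nH]c1=O` was tested in an ADME assay on MT4 cells (Homo sapiens) for cytotoxicity, read by MTT assay; a lower number here means that less compound is tolerated, a higher number that more compound is tolerated. In this assay compound 1 gives >= 246000 nM, which is a limit of the assay rather than a number. Compound 2 `Cc1c(Cc2cccc(Br)c2)nc(SCc2ccc([N+](=O)[O-])cc2)[nH]c1=O` carries 3-bromophenyl in place of 2-bromophenyl on a saturated chain carbon bound to an aromatic carbon. In this assay compound 2 gives > 280000 nM, again a limit. The resulting step that the two limits leave unreadable from compound 1 to compound 2 cannot be sized, because compound 1 sits at the limit of >= 246000 nM in this assay, at which 1 of the 3 values shown sits, and compound 2 sits at the limit of > 280000 nM in this assay, at which 1 of the 3 values shown sits.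

Compound 3 `CCc1c(Cc2ccccc2Br)nc(SCc2ccc(OC)cc2)[nH]c1=O` shares its core with compound 1 only in part; the difference between the two cores is not broken down here. In this assay, going by the values given here, compound 3 gives 165000 nM, the only value in the set that is a number rather than a limit.

Compound 4 `CCc1c(Cc2cccc(Br)c2)nc(SCc2ccc(OC)cc2)[nH]c1=O` is not yet measured and carries 3-bromophenyl in place of 2-bromophenyl on a saturated chain carbon bound to an aromatic carbon, the same change as from compound 1 to compound 2. The step is expected to be small, a 1.2-fold higher number from compound 3 to compound 4 (0.06 log units; within the scatter), resting on compound 1 and compound 2, both of which stay at limits. Compound 1 gives >= 246000 nM, a limit. Compound 2 gives > 280000 nM, a limit. Compound 4 is estimated at 190000 nM, within 95000 nM to 380000 nM.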

Compound 4, half-maximal cytotoxic concentration: 201000 nM
Beside the measured number, compound 4's estimate is 1.1-fold (0.02 log units) below it, within the range that was stated.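

In this assay, replacing 2-bromophenyl with 3-bromophenyl on a saturated chain carbon bound to an aromatic carbon gives a 1.2-fold higher number from compound 3 to compound 4 (0.09 log units; within the scatter), so on the core of compound 3 the change leaves the reading where it was within the usual scatter. On the core of compound 1 the same change cannot be sized, because compound 1 stands at a limit rather than a number: the limit of >= 246000 nM in this assay, at which 1 of the 4 values shown sits. Going by these compounds alone, compound 2 stands at a limit too, so the one readable step has no second step to be set against, and the data neither confirm nor refute that the change behaves alike on both cores: the limit of > 280000 nM in this assay, at which 1 of the 4 values shown sits.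

The two cores differ in more than one place, so the compounds shown leave open which of those differences, if any, bears on how well the cells tolerate these compounds. They also leave open how the reading would respond if an amine or a carboxylic acid stood in place of the bromine on the benzyl group.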